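Pyrazole Chalcones: A Third Methoxy on the Aryl Ketone

A few compounds are considered here, and "the series" means these few. Any claim that something is new, unique, unknown or untested is made for them only; others in the source may bear on it.

The study describes three measured compounds that share a pyrazolyl-propenone arrangement and one that awaits testing. Compound 1 `COc1ccc(-c2cc(/C=C/C(=O)c3ccc(N)cc3)[nH]n2)cc1` was measured in a functional assay on KM12 cells (Homo sapiens) for inhibition, read by sulforhodamine B assay, with a stated time of 48 h (a higher number here means a weaker inhibitor of growth, a lower number a stronger inhibitor of growth), and gave 3420 nM. Compound 3 `COc1ccc(-c2cc(/C=C/C(=O)c3ccc(N)cc3)[nH]n2)cc1OC` differs from it by methoxy in place of hydrogen on an aromatic carbon; in this assay compound 3 gave 3350 nM, so the step of a 1.0-fold lower number from compound 1 to compound 3 (0.01 log units; within the scatter). Compound 2 `COc1ccc(C(=O)/C=C/c2cc(-c3cc(OC)c(OC)c(OC)c3)n[nH]2)cc1OC` belongs to a different core; the difference between the two cores is not broken down here. In this assay compound 2 gave 2410 nM, and its values and those of compound 1 and compound 3 lie within the scatter of one another.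

Compound 4 `COc1cc(C(=O)/C=C/c2cc(-c3cc(OC)c(OC)c(OC)c3)n[nH]2)cc(OC)c1OC` is not yet measured. It differs from compound 2 by methoxy in place of hydrogen on an aromatic carbon. This is the same kind of change as that from compound 1 to compound 3, though here the position is also meta to a methoxy group. Because the earlier step of a 1.0-fold lower number from compound 1 to compound 3 (0.01 log units; within the scatter) stayed within the scatter, the step from compound 2 to compound 4 is expected to be a 1.0-fold lower number from compound 2 to compound 4 (0.00 log units; within the scatter). Compound 4 is therefore estimated to give 2400 nM in this assay, with a range from 1200 nM to 4800 nM.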

Compound 4, concentration for total growth inhibition: 2930 nM
Compound 4: middle estimate off by 1.2-fold (0.09 log units), on the low side, within the range that was stated.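

In this assay, methoxy in place of hydrogen on an aromatic carbon gave a 1.2-fold higher number from compound 2 to compound 4 (0.08 log units; within the scatter), and this step, ortho to one methoxy group and meta to another, stayed within the scatter. Set beside the earlier case, the same change gave steps on the two cores that cannot be told apart: the same change on two cores in this assay, a 1.0-fold lower number (0.01 log units; within the scatter) from compound 1 to compound 3 and a 1.2-fold higher number (0.08 log units; within the scatter) from compound 2 to compound 4, 1.2-fold (0.09 log units) apart, within the scatter of two such steps. Within the data shown here, this shows only that the change made no readable difference on either core; with two pairs, both within the scatter, it does not show that the change would have so little effect on another core or at another place on the ring.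

The compounds shown leave open what a different group would do at this place, such as a hydroxyl, an ethoxy or a chlorine in place of the methoxy. They also leave open whether these steps would look the same in any other cell line.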